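The source may hold more compounds than are shown below. What is called first, only, known or untested is meant among the compounds shown, and "the series" means these compounds.

Series notes. Compound 1 `COc1ncc(-c2ccc3c(c2)N(c2ccc(C)cc2)C(=O)CO3)cc1NS(=O)(=O)c1ccc(F)cc1` and compound 2 `COc1ncc(-c2ccc3c(c2)N(C2CCCCC2)C(=O)CO3)cc1NS(=O)(=O)c1ccc(F)cc1` share one core and differ in a single place: 4-methylphenyl in place of cyclohexyl on an amide-type nitrogen in a ring. In a functional assay on HepG2 cells (Homo sapiens) for antiproliferative activity, read by MTT assay, with a stated time of 72 h (on this read-out higher numbers stand for weaker inhibition and lower numbers for stronger inhibition), compound 1 gives 28300 nM. For compound 2 the read-out is a limit of the assay and not a number, > 40000 nM. The measured step is an at least 1.4-fold lower number from compound 2 to compound 1 (0.15 log units; that floor lies within the scatter), and it can be read only as a floor because the limit of > 40000 nM in this assay, at which 2 of the 3 values shown sit, fixes one side of it.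

Compound 3 `O=C1COc2ccc(-c3cnc4ccccc4c3)cc2N1C1CCCCC1` carries a different core; the difference between the core of compound 3 and the core of compound 2 is not broken down here. For compound 3 the read-out in this assay is again a limit of the assay, > 40000 nM.

Compound 4 `Cc1ccc(N2C(=O)COc3ccc(-c4cnc5ccccc5c4)cc32)cc1` is not yet measured. It stands to compound 3 as compound 1 stands to compound 2: 4-methylphenyl in place of cyclohexyl on an amide-type nitrogen in a ring. The two place descriptions read alike word for word, so this is the same change made on a second core. What the first occurrence supports is thin, since the only numbered point of the pair, compound 1, sits in the weak range and its partner is a limit.

For compound 4 the expected step in this assay is an at least 1.3-fold lower number from compound 3 to compound 4 (0.12 log units; that floor lies within the scatter). That expectation rests on compound 1 at 28300 nM. It rests as well on the measured step of an at least 1.4-fold lower number from compound 2 to compound 1 (0.15 log units; that floor lies within the scatter), which is only a floor. Compound 4 is estimated at 30000 nM, between 12000 nM and 80000 nM, with a real chance that only a limit is returned.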

Compound 4, half-maximal inhibitory concentration: > 40000 nM
Compound 4: no number, only a limit; the forecaster's own chance of this, stated with the estimate: 55%; middle value at least 1.3-fold (0.12 log units) from the limit.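

Compound 3 and compound 4 both return only a limit of the assay in this assay, so no step can be read between them, because neither value is a number: the limit of > 40000 nM in this assay, at which 3 of the 4 values shown sit.

The compounds shown leave open whether 4-methylphenyl in place of cyclohexyl on an amide-type nitrogen in a ring changes the read-out at all on the core of compound 3, and how far compounds 2, 3 and 4 lie from that limit.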